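Swapping the Benzyl Ring on an Aortic Alpha-1D Antagonist

The source may hold more compounds than are shown below. What is called first, only, known or untested is meant among the compounds shown, and "the series" means these compounds.

Compound 1 `COc1cccc(OC)c1OCCNCCOc1ccccc1OCc1cccc(Cl)c1` gives 8.72 in a functional assay on thoracic aorta for antagonist activity at Alpha-1D adrenergic receptor (Rattus norvegicus); a lower number here means a less potent compound, a higher number a more potent compound, by a factor of ten per unit of this negative logarithm. Its nearest neighbour, compound 2 `COc1cccc(OC)c1OCCNCCOc1ccccc1OCc1ccccc1C`, gives 8.64, and the step of a number 0.08 log units lower from compound 1 to compound 2 (within the scatter) shows the two within the usual scatter, so neither can be called the more potent. Compound 3 `CCOc1ccc(COc2ccccc2OCCNCCOc2c(OC)cccc2OC)cc1` has not yet been tested. It differs from compound 1 by 4-ethoxyphenyl in place of 3-chlorophenyl on a saturated chain carbon bound to an oxygen on an aromatic ring. Among the compounds with values here, the only measured step that touches this part of the molecule is the one from compound 1 to compound 2, and it was too small to rise above the scatter. Within the data shown here, no measured pair shows the 4-ethoxyphenyl group itself, so the expectation rests on that single small step. Compound 3 is therefore expected to land close to compound 1, with a step of a number 0.12 log units lower from compound 1 to compound 3 (within the scatter) that stays within the scatter. The estimate for compound 3 in this assay is 8.6, with a range from 8.1 to 9.1.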

Compound 3, negative logarithm of the antagonist equilibrium constant: 9.11
The estimate for compound 3 lay 0.51 log units below the measured number, outside the stated range (above it).
By their numbers in this assay, from the lowest: compounds 2 and 1 (each within the scatter of the next); then compound 3.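

Unlike the earlier pair, whose step stayed within the scatter, this change shows that the group at this place can move the number: in this assay, 4-ethoxyphenyl in place of 3-chlorophenyl gives a number 0.39 log units higher from compound 1 to compound 3 (beyond the scatter) and in place of 2-methylphenyl gives a number 0.47 log units higher from compound 2 to compound 3 (beyond the scatter). Both steps are modest but beyond the scatter, so compound 3 is the most potent of the three, and the carbon-only substituents on the ring of compounds 1 and 2 do not mark a ceiling. The entering group also differs in its heavy atoms and its hydrogen-bond acceptor, yet nothing here links any of these differences to the higher number.

On these data alone, what remains open is whether the ethoxy group itself matters or where it sits on the ring. A comparison with 4-chlorophenyl, 4-methoxyphenyl or 3-ethoxyphenyl at this place would begin to separate those two questions.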